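Trimming the Ring Amine: From Azepanyl to Diethylamino

A few compounds are considered here, and "the series" means these few. Any claim that something is new, unique, unknown or untested is made for them only; others in the source may bear on it.

Measured so far, in a functional assay on HEK293 cells for activation of melanin-concentrating hormone receptor 1 (Rattus norvegicus), read by inositol phosphate accumulation; a higher number here means that more compound is needed for the effect, a lower number that less compound is needed:
- compound 1, `O=C(CCc1ccc(C(F)(F)F)cc1)Nc1ccc2nc(N3CC4CC3CN4)ccc2c1`, gives 490 nM
- compound 2, `CN(c1ccc2cc(NC(=O)CCc3ccc(C(F)(F)F)cc3)ccc2n1)C1CCCCC1`, gives 1200 nM
- compound 3, `O=C(CCc1ccc(C(F)(F)F)cc1)Nc1ccc2nc(N3CCCCCC3)ccc2c1`, gives 1800 nM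

Compound 3 carries the highest of the three numbers. Its nearest neighbour is compound 2, and the gap between them, a 1.5-fold higher number from compound 2 to compound 3 (0.18 log units; within the scatter), sits within the usual scatter, so the two cannot be told apart. The gap to compound 1, a 3.7-fold higher number from compound 1 to compound 3 (0.57 log units; beyond the scatter), lies beyond the scatter.

Compound 4, `CCN(CC)c1ccc2cc(NC(=O)CCc3ccc(C(F)(F)F)cc3)ccc2n1`, differs from compound 3 in one place: diethylamino in place of azepan-1-yl on an aromatic carbon. Both groups are tertiary amines attached at the same aromatic carbon, next to the ring nitrogen.

Among the compounds with values here, two of the earlier steps bear on this change. The step of a 1.5-fold higher number from compound 2 to compound 3 (0.18 log units; within the scatter) shows that exchanging one tertiary amine for another of similar size moved the number only within the scatter. The step of a 3.7-fold higher number from compound 1 to compound 3 (0.57 log units; beyond the scatter), and likewise a 2.4-fold higher number from compound 1 to compound 2 (0.39 log units; beyond the scatter), shows that a larger shift came with the group holding two nitrogen atoms. Diethylamino, like azepan-1-yl, holds one nitrogen, so the expected step of a 1.2-fold lower number from compound 3 to compound 4 (0.08 log units; within the scatter) is small and not expected to clear the scatter. Compound 4 is therefore estimated to give 1500 nM, within a range from 600 nM to 4000 nM.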

Compound 4, half-maximal effective concentration: 830 nM
Beside the measured number, compound 4's estimate is 1.8-fold (0.26 log units) above it; low and high end bracket the measured number.
By their numbers in this assay, from the lowest: compounds 1, 4, 2 and 3 (each within the scatter of the next, the first and the last beyond it).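

In this assay, replacing the seven-membered ring of azepan-1-yl with the open, ring-free diethylamino group, which has fewer heavy atoms, gives a 2.2-fold lower number from compound 3 to compound 4 (0.34 log units; beyond the scatter) and so clears the scatter. Within the data shown here, this is the first step beyond the scatter between two groups that each hold one nitrogen, so the nitrogen count alone does not settle the number at this position. The steps (a 1.4-fold lower number from compound 2 to compound 4 (0.16 log units; within the scatter)) and (a 1.7-fold higher number from compound 1 to compound 4 (0.23 log units; within the scatter)) both stay within the scatter, so diethylamino cannot be told apart from either cyclohexyl(methyl)amino or the group holding two nitrogen atoms, and no measurement shown explains why these groups compare as they do.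

A single step cannot show whether the ring itself or the number of heavy atoms matters more, and pyrrolidin-1-yl, a ring amine with fewer carbons than azepan-1-yl, or dimethylamino, a shorter open amine than diethylamino, would help to separate the two. Piperazin-1-yl would also test whether a second nitrogen in a simple, unbridged ring gives a number close to that of compound 1.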